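The source may hold more compounds than are shown below. What is called first, only, known or untested is meant among the compounds shown, and "the series" means these compounds.

Compound 1 `Cc1nc(N)c2c(-c3ccoc3)cn([C@@H]3O[C@H](CO)[C@@H](O)[C@H]3O)c2n1` carries furan-3-yl on the shared core. In a functional assay on K562 cells (Homo sapiens), read by MTT assay, with a stated time of 72 h (a higher number here means a weaker inhibitor, a lower number a stronger inhibitor), compound 1 gives only a limit, > 20000 nM. Compound 2 `Cc1nc(N)c2c(-c3cc4ccccc4o3)cn([C@@H]3O[C@H](CO)[C@@H](O)[C@H]3O)c2n1` differs by 1-benzofuran-2-yl in place of furan-3-yl on an aromatic carbon and in this assay compound 2 gives 4990 nM, so the step is an at least 4.0-fold lower number from compound 1 to compound 2 (0.60 log units; beyond the scatter). Compound 3 `Nc1nc(N)c2c(-c3ccoc3)cn([C@@H]3O[C@H](CO)[C@@H](O)[C@H]3O)c2n1` differs from compound 1 by amino in place of methyl on an aromatic carbon. In this assay compound 3 also gives only a limit, > 20000 nM. Accordingly a step that the two limits leave unreadable from compound 1 to compound 3, since the limit of > 20000 nM in this assay, at which 2 of the 3 values shown sit, holds both values. Compound 4 `Nc1nc(N)c2c(-c3cc4ccccc4o3)cn([C@@H]3O[C@H](CO)[C@@H](O)[C@H]3O)c2n1` is not yet measured; it differs from compound 3 by 1-benzofuran-2-yl in place of furan-3-yl on an aromatic carbon, the same change as from compound 1 to compound 2, at the same place. The expected step is an at least 3.3-fold lower number from compound 3 to compound 4 (0.52 log units; beyond the scatter), resting on an at least 4.0-fold lower number from compound 1 to compound 2 (0.60 log units; beyond the scatter). Compound 4 is expected near 6000 nM, with a range from 1500 nM to 20000 nM.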

Compound 4, half-maximal inhibitory concentration: > 20000 nM
Compound 4: a limit, no number; the forecaster's own chance of this, stated with the estimate: 30%; at least 3.3-fold (0.52 log units) between middle value and limit.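

In this assay compound 4 gives only a limit, > 20000 nM. Amino in place of methyl, with 1-benzofuran-2-yl held constant, gives an at least 4.0-fold higher number from compound 2 to compound 4 (0.60 log units; beyond the scatter). 1-Benzofuran-2-yl in place of furan-3-yl therefore has a readable effect only on the core of compound 1, while the steps that join limit to limit cannot be read, so the result neither shows that the change carries to the core of compound 3 nor measures how much of it is lost there, since these values all stop at the same limit: the limit of > 20000 nM in this assay, at which 3 of the 4 values shown sit.

Still open, as far as these compounds go, is whether an ethyl group or a hydrogen in place of methyl would keep a value as low as that of compound 2. Also open, from the compounds shown here alone, is whether a phenyl group in place of 1-benzofuran-2-yl would give a readable value on either core.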